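Extending the amide alkyl on compound 1

The compounds below may be only part of what the source reports. "The series", "measured", "known", "first", "only" and "open" are said of these compounds alone.

Among the measured compounds shown here, compound 1 `CNC(=O)c1cc(Oc2ccc(NC(=O)c3cc4cccnc4n(-c4ccccc4F)c3=O)cc2)ccn1` is the stronger of the two compounds measured so far. In a functional assay on HT-29 cells (Homo sapiens) for antiproliferative activity, read by MTT assay, with a stated time of 72 h (a lower number here means a stronger inhibitor, a higher number a weaker inhibitor), compound 1 gives 260 nM, the lowest of the two numbers. For the measured compounds named here, its only measured neighbour is compound 2 `CNC(=O)c1cc(Oc2ccc(NC(=O)c3cc4cccnc4n(-c4ccc(C(F)(F)F)cc4Cl)c3=O)cc2)ccn1`, which in this assay gives 3190 nM; the step of a 12-fold higher number from compound 1 to compound 2 (1.09 log units; beyond the scatter) is large and comes from exchanging the group on the aromatic nitrogen of the shared core. Compound 3 `CCCNC(=O)c1cc(Oc2ccc(NC(=O)c3cc4cccnc4n(-c4ccccc4F)c3=O)cc2)ccn1` keeps that part of compound 1 unchanged and differs elsewhere: ethyl in place of hydrogen on a saturated chain carbon bound to an amide-type nitrogen, so that the methylcarbamoyl becomes a propylcarbamoyl. Going by the values given here, the single measured step concerns a different position and does not bear on this change, so no measured comparison informs the size of the step to compound 3. With nothing in the data pointing either way, compound 3 is expected to give a number close to that of compound 1, possibly somewhat higher, estimated as 500 nM with a range from 150 nM to 1700 nM. This corresponds to an expected step of a 1.9-fold higher number from compound 1 to compound 3 (0.28 log units; within the scatter), which may fall within the scatter.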

Compound 3, half-maximal inhibitory concentration: 200 nM
For compound 3 the middle estimate is 2.5-fold (0.40 log units) above the measured one, and the stated range covers the measured number.
By their numbers in this assay, from the lowest: compounds 3 and 1 (each within the scatter of the next); then compound 2.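

Replacing methylcarbamoyl with propylcarbamoyl, the only change shown at this position, places ethyl in place of hydrogen on a saturated chain carbon bound to an amide-type nitrogen, and in this assay it gives a 1.3-fold lower number from compound 1 to compound 3 (0.11 log units; within the scatter) with no separation between the two compounds. Within this pair, the added ethyl leaves the antiproliferative read-out unchanged within the scatter, whereas exchanging the group on the aromatic nitrogen gives a 12-fold higher number from compound 1 to compound 2 (1.09 log units; beyond the scatter) and lies beyond it. Nothing at hand accounts for either result.

What the compounds shown leave open is whether the same holds for a longer chain such as pentyl, a branched group such as isopropyl, a ring such as cyclopropyl, or a chain ending in an amine or a carboxylic acid. They also leave open whether propylcarbamoyl would give the same picture when combined with the 2-chloro-4-(trifluoromethyl)phenyl group, and whether the amide hydrogen can be replaced at all.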